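A few compounds are considered here, and "the series" means these few. Any claim that something is new, unique, unknown or untested is made for them only; others in the source may bear on it.

Compound 1 `Cc1ccc(S(=O)(=O)N[C@@H](CC(=O)NC(C)(C)C)C(=O)NCCNC(=O)c2c(O)cccc2F)cc1` gives > 11000 nM in an ADME assay on HepG2 cells (Homo sapiens) for cytotoxicity (a higher number here means that more compound is needed for the effect, a lower number that less compound is needed), a limit of the assay rather than a number.
Compound 2 `Cc1ccc(S(=O)(=O)N[C@@H](CC(=O)NC(C)(C)C)C(=O)NCCNC(=O)c2cc(Cl)ccc2Cl)cc1` gives > 11000 nM in this assay, again a limit.
Compound 3 `Cc1ccc(S(=O)(=O)N[C@@H](CC(=O)NC(C)(C)C)C(=O)NCCNC(=O)c2ccc(F)cc2)cc1` gives > 11000 nM in this assay, again a limit.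

Compound 2 therefore stands nowhere in particular on the numbers shown: its own value is a limit, and the two further values shown are limits as well, which is the limit of > 11000 nM in this assay, at which 3 of the 3 values shown sit. The steps that touch compound 2, a step that the two limits leave unreadable from compound 1 to compound 2 and a step that the two limits leave unreadable from compound 2 to compound 3, are both left unreadable by the limits, and a step that the two limits leave unreadable from compound 1 to compound 3 is unreadable for the same reason. Within the data shown here, no measured step in this assay has a readable size.

Compound 4 `Cc1ccc(S(=O)(=O)N[C@@H](CC(=O)NC(C)(C)C)C(=O)NCCNC(=O)c2cccc(C(F)(F)F)c2)cc1` differs from compound 2 by 3-(trifluoromethyl)phenyl in place of 2,5-dichlorophenyl on a carbonyl carbon. The three measured variations at this position, the 2-fluoro-6-hydroxyphenyl, 2,5-dichlorophenyl and 4-fluorophenyl, all end at the limit, and nothing in the measured series gives a direction or a size for the step to the 3-(trifluoromethyl)phenyl. The expectation for compound 4 is that it also ends at the limit, with a step that the limit leaves unreadable from compound 2 to compound 4 expected to be no step beyond the scatter. Compound 4 is estimated at 15000 nM, within 8000 nM to 40000 nM.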

Compound 4, half-maximal effective concentration: > 11000 nM
Compound 4: a limit, no number; the forecaster's own chance of this, stated with the estimate: 85%; the middle value lies beyond the limit too.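

In this assay compound 4 gives > 11000 nM, a limit, so none of its steps to compound 1, compound 2 or compound 3 can be read: the limit of > 11000 nM in this assay, at which 4 of the 4 values shown sit.

The compounds shown leave open whether the four groups on the carbonyl carbon differ at all in this assay.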